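This account rests on a few compounds, and the source may have more. Where it says the series, first, only, none or still open, it means among the compounds named here.

Three compounds share one core and were all tested in an assay on isolated protein for inhibition of thyroid hormone receptor alpha (Homo sapiens), read by fluorescence polarization; a lower number here means a stronger inhibitor, a higher number a weaker inhibitor. Compound 1 `CS(=O)(=O)c1ccc(C(=O)N2CCC(C(=O)N3CCN(c4ccc(F)cc4)CC3)CC2)cc1[N+](=O)[O-]` returned only the limit of the assay, > 60000 nM. Compound 2 `CC1CCN(C(=O)CCNC(=O)c2ccc(S(C)(=O)=O)c([N+](=O)[O-])c2)CC1` likewise gave no number but the limit, > 60000 nM. Compound 3 `CS(=O)(=O)c1ccc(C(=O)NCCCC(=O)N2CCCCC2)cc1[N+](=O)[O-]` also reached only the limit, > 60000 nM. Compound 2 therefore stands at the limit, and nothing places it relative to the other two. Among the compounds with values here, the one step between measured compounds that differ in a single place, a step that the two limits leave unreadable from compound 2 to compound 3, cannot be read, because of the limit of > 60000 nM in this assay, at which 3 of the 3 values shown sit. The account now turns to compound 4 `CS(=O)(=O)c1ccc(C(=O)NCCC(=O)N2CCCc3ccccc32)cc1[N+](=O)[O-]`, which differs from compound 2 by 1,2,3,4-tetrahydroquinolin-1-yl in place of 4-methylpiperidin-1-yl on a carbonyl carbon. Within the data shown here, the step from compound 2 to compound 3 concerns the group on the same carbonyl carbon, yet its size is not readable, so no measured step gives the change a size. Among the measured compounds shown here, with every value at the limit, no step in this assay beyond the scatter is expected in either direction, and compound 4 is expected to sit at 80000 nM, within 30000 nM to 300000 nM. The step that this estimate implies, a step that the limit leaves unreadable from compound 2 to compound 4, is expected to be no larger than the scatter.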

Compound 4, half-maximal inhibitory concentration: > 60000 nM
Compound 4: no number, only a limit; the forecaster's own chance of this, stated with the estimate: 85%; the middle value lies beyond the limit too.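

No new step can be read from compound 2 to compound 4, because each compound returns only a limit: (the limit of > 60000 nM in this assay, at which 4 of the 4 values shown sit). The compounds shown leave open whether 1,2,3,4-tetrahydroquinolin-1-yl in place of 4-methylpiperidin-1-yl changes inhibition at all in this assay, since none of them gives a number.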